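The compounds below may be only part of what the source reports. "The series", "measured", "known", "first", "only" and "open" are said of these compounds alone.

Measured in an ADME assay on MT4 cells (Homo sapiens) for cytotoxicity, read by MTT assay, with a stated time of 5 days; a lower number here means that less compound is tolerated, a higher number that more compound is tolerated:
- compound 1 `N#Cc1ccc(Nc2nccc(OCC(=O)Nc3ccc(Cl)cc3)n2)cc1`: 162000 nM
- compound 2 `COc1ccc(NC(=O)COc2ccnc(Nc3ccc(C#N)cc3)n2)cc1`: > 333000 nM, a limit of the assay
- compound 3 `Cc1cc(OCC(=O)Nc2ccc(Cl)cc2)nc(Nc2ccc(C#N)cc2)n1`: 2630 nM

Compound 3, at 2630 nM, stands lowest of the actual numbers in this assay. The measured step to it is a 62-fold lower number from compound 1 to compound 3 (1.79 log units; beyond the scatter), with methyl in place of hydrogen on an aromatic carbon. Compound 2 offers only a limit.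

Compound 4 `Cc1cc(OCC(=O)Nc2ccc(C#N)cc2F)nc(Nc2ccc(C#N)cc2)n1` keeps that methyl and changes the other end of the molecule: 4-cyano-2-fluorophenyl in place of 4-chlorophenyl on an amide-type nitrogen. In short, 4-cyano-2-fluorophenyl stands in place of 4-chlorophenyl on an amide-type nitrogen. The large methyl step therefore does not bear directly on this change. The nearest guide is an at least 2.0-fold higher number from compound 1 to compound 2 (0.31 log units; beyond the scatter), where methoxy replaces the same chloro, though methoxy is not the group that enters here. On that single precedent, a modest rise is expected rather than a large move. The expected change is a 2.3-fold higher number from compound 3 to compound 4 (0.36 log units; beyond the scatter). The estimate for compound 4 is 6000 nM, with an expected range of 1500 nM to 30000 nM.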

Compound 4, half-maximal cytotoxic concentration: > 310000 nM
Compound 4 was reported as a limit (the forecaster's own chance of this, stated with the estimate: 10%); middle value at least 51-fold (1.71 log units) from the limit.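

With the methyl kept, 4-cyano-2-fluorophenyl in place of 4-chlorophenyl on the amide-type nitrogen gives in this assay an at least 110-fold higher number from compound 3 to compound 4 (2.07 log units; beyond the scatter), so a change at this end of the molecule alone is enough to produce a large move. Compound 4 gives > 310000 nM, which is a limit of the assay and not a number: the limit of > 310000 nM in this assay, at which 1 of the 4 values shown sits. The methyl is present in compound 4 as well, so the methyl alone does not set the low number of compound 3; the group on the amide-type nitrogen matters too.

Going by these compounds, how far compound 4 lies past its limit remains unknown, and with it the full size of the step. On these data alone, the nitrile and the fluorine enter together, so it stays open whether either one alone, or an amine or a carboxylic acid in their place, would give the same move.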